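From methyl to cyclopropyl on an aromatic nitrogen

The compounds below may be only part of what the source reports. "The series", "measured", "known", "first", "only" and "open" are said of these compounds alone.

Among the compounds with values here, compound 1 (`Cc1cnc(NC(=O)c2cc(Oc3ccc(S(C)(=O)=O)cc3)c3cn(C)nc3c2)cn1`) supplies the only number available: in an ADME assay on MDCKII-LE cells (Canis lupus familiaris) for permeability (on this read-out lower numbers stand for lower permeability and higher numbers for higher permeability), compound 1 gives 20.4 10^-6 cm/s as its reading. Compound 2 (`Cc1cnc(NC(=O)c2cc(Oc3ccc(S(N)(=O)=O)cc3)c3cn(C)nc3c2)cn1`) offers no comparison, as compound 2 stands at "not determined" (no result reported) in this assay and so leaves compound 1 with nothing to be ranked against. Compound 3 (`Cc1cnc(NC(=O)c2cc(Oc3ccc(S(C)(=O)=O)cc3)c3cn(C4CC4)nc3c2)cn1`) keeps the core of compound 1 and has cyclopropyl in place of methyl on an aromatic nitrogen. Within the data shown here, no measured pair shows what such a change does in this assay, so the expectation rests on compound 1 at 20.4 10^-6 cm/s alone, and no step beyond the scatter is expected in either direction. The estimated 1.0-fold higher number from compound 1 to compound 3 (0.01 log units; within the scatter) is therefore small. For compound 3 the expected value is 21 10^-6 cm/s with an estimated range from 11 10^-6 cm/s to 36 10^-6 cm/s in this read-out.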

Compound 3, apparent permeability in the MDCKII-LE assay: 15.5 10^-6 cm/s
Beside the measured number, compound 3's estimate is 1.4-fold (0.13 log units) above it; measured number inside the range.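

In the MDCKII-LE assay, the first step read at this position is a 1.3-fold lower number from compound 1 to compound 3 (0.12 log units; within the scatter), so cyclopropyl in place of methyl on an aromatic nitrogen gives two compounds that this read-out does not separate. In a physicochemical assay for solubility, measured as kinetic solubility (a higher number here means a more soluble compound, a lower number a less soluble compound), the same change gives a very different picture, as compound 1 reads 454000 nM and compound 3 reads 500 nM in this read-out: the measured solubility of compound 1, 454000 nM, and of compound 3, 500 nM, a 910-fold lower number (2.96 log units; beyond the scatter). Compound 1 and compound 3 thus show that a single change on this nitrogen can stay within the scatter on one read-out and lie far beyond it on another.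

What the compounds shown leave open is whether an open chain such as ethyl or isopropyl on the same nitrogen would give a step of this size in the physicochemical assay, or whether it is tied to the three-membered ring. Nor do they show whether a group carrying an amine there would keep the reading in the MDCKII-LE assay.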